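Three Limits and a Fourth Aryl Variant Awaiting Measurement

The source may report more compounds than this note shows. Statements on the series, on what has been measured and on what is new or still open speak of the compounds shown alone.

The three measured compounds share one core and differ only in the group on an aromatic nitrogen of a five-membered aromatic ring with 3 nitrogen. Compound 1 `N#CC1=C(N)Oc2c(c3nc4ccccc4nc3c3ccccc23)C12C(=O)N(Cc1cnnn1-c1ccccc1Cl)c1ccccc12` carries a 2-chlorophenyl. In an ADME assay on HUVEC cells (Homo sapiens) for antiproliferative activity, read by MTT assay, with a stated time of 48 h (a higher number here means a weaker inhibitor, a lower number a stronger inhibitor), compound 1 gives > 50000 nM, which is a limit of the assay and not a number. Compound 2 `N#CC1=C(N)Oc2c(c3nc4ccccc4nc3c3ccccc23)C12C(=O)N(Cc1cnnn1-c1cccc(Br)c1)c1ccccc12` carries a 3-bromophenyl. In this assay compound 2 gives > 50000 nM, again a limit. Compound 3 `N#CC1=C(N)Oc2c(c3nc4ccccc4nc3c3ccccc23)C12C(=O)N(Cc1cnnn1-c1ccc(N)cc1)c1ccccc12` carries a 4-aminophenyl. In this assay compound 3 gives > 50000 nM, also a limit. Because of the limit of > 50000 nM in this assay, at which 3 of the 3 values shown sit, none of the steps among these three can be read: a step that the two limits leave unreadable from compound 1 to compound 2, a step that the two limits leave unreadable from compound 1 to compound 3 and a step that the two limits leave unreadable from compound 2 to compound 3. Compound 3 thus stands at the same limit as the other two, with no number of its own.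

Compound 4 `Cc1ccc(Cl)cc1-n1nncc1CN1C(=O)C2(C(C#N)=C(N)Oc3c2c2nc4ccccc4nc2c2ccccc32)c2ccccc21` has not yet been measured. It differs from compound 3 by 5-chloro-2-methylphenyl in place of 4-aminophenyl on an aromatic nitrogen. The measured steps that bear on this change are all unreadable, and none of them offers a sign that varying the aryl group on this nitrogen moves the read-out in this assay beyond the scatter. The account therefore expects compound 4 to sit at the limit as well, with an estimate of 50000 nM and a range from 20000 nM to 120000 nM. The expected step is a number no higher from compound 3 to compound 4 (the limit leaves the size open).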

Compound 4, half-maximal inhibitory concentration: > 50000 nM
Compound 4: only a limit was reported; the forecaster's own chance of this, stated with the estimate: 80%; the middle value lies on the limit itself.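

Compound 4 gives a limit in this assay, not a number, so its steps to compound 1, compound 2 and compound 3 cannot be read, because all four compounds rest at the same limit: the limit of > 50000 nM in this assay, at which 4 of the 4 values shown sit.

The compounds shown leave open whether any aryl group on this nitrogen gives a measurable number in this assay, and how large any difference among these four compounds would be.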